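The source may hold more compounds than are shown below. What is called first, only, known or untested is meant among the compounds shown, and "the series" means these compounds.

Two compounds carry data so far in a physicochemical assay for solubility, read by HPLC, in phosphate buffer, measured as kinetic solubility, with a stated time of 1 h, at pH 7.4, tested at 250 uM (a higher number here means a more soluble compound, a lower number a less soluble compound), and neither gives an exact number. Compound 1 (`CC(C)CNC(=O)n1cc(-c2ccccc2)oc1=O`) reads < 1000 nM and this is a limit of the assay. Compound 2 (`O=C(NCCCCc1ccccc1)n1cc(-c2ccc(F)cc2)oc1=O`) reads < 1000 nM and this too is a limit of the assay. The whole record is thus the limit of < 1000 nM in this assay, at which 2 of the 2 values shown sit, and compound 2 has no firmer position than that. Within the data shown here, no step between measured compounds is available for calibration.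

Compound 3 (`COc1cc(-c2cn(C(=O)NCCCCc3ccccc3)c(=O)o2)ccc1F`) differs from compound 2 in one place, where 4-fluorophenyl becomes 4-fluoro-3-methoxyphenyl. This puts methoxy in place of hydrogen on an aromatic carbon, ortho to a fluoro group (methoxy in place of hydrogen on an aromatic carbon) and meta to a large group. With only the limit of compound 2 as an anchor, no change beyond the usual scatter is expected in this assay and neither direction is favoured. The expected change, a step that the limit leaves unreadable from compound 2 to compound 3 on this estimate, is therefore small. Compound 3 is estimated at 700 nM with an expected range from 250 nM to 1800 nM. For compound 3 a limit of the assay is also expected to be the likelier outcome.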

Compound 3, solubility: < 1000 nM
Compound 3: only a limit was reported; the forecaster's own chance of this, stated with the estimate: 70%; the middle value lies beyond the limit too.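

No step can be read from compound 2 to compound 3 in this assay, as each of the two compounds gives only a limit. The compounds shown leave open where any of them truly lies and whether methoxy in place of hydrogen on an aromatic carbon alters the read-out, with the whole record resting on one value: the limit of < 1000 nM in this assay, at which 3 of the 3 values shown sit.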